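Swapping an acyl group for a pyridine on the oxazole-type core

This account rests on a few compounds, and the source may have more. Where it says the series, first, only, none or still open, it means among the compounds named here.

Measured so far:
- compound 1, `O=C(CCCCCCc1ccccc1)c1nnc(-c2ccccc2)s1`: > 10000 nM
- compound 2, `CC(C)(C)C(=O)c1coc(C(=O)CCCCCCc2ccccc2)n1`: 479 nM

Both compounds were tested in an assay on HEK-293T cells for inhibition of diacylglycerol lipase-alpha (Homo sapiens), read by colorimetric assay; on this read-out higher numbers stand for weaker inhibition and lower numbers for stronger inhibition. Compound 1 gives only a limit there, > 10000 nM, which means no number could be fixed for it. For the measured compounds named here, compound 2 stands as the only real number in this set, at 479 nM in this assay, and it is therefore the single reference point; the other entry sits at the limit of > 10000 nM in this assay, at which 1 of the 2 values shown sits.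

Compound 3, `O=C(CCCCCCc1ccccc1)c1nc(-c2ccncc2)co1`, has not yet been measured. It keeps the core of compound 2 and its long chain ending in a benzene ring, but one group is exchanged: pyridin-4-yl in place of (tert-butyl)carbonyl on an aromatic carbon. The group that leaves carries a carbonyl; the group that enters is an aromatic ring with one nitrogen.

Going by the values given here, with no measured step between the two, the expected size can only be guessed from the structures. A weakening by a moderate step is expected, a 6.3-fold higher number from compound 2 to compound 3 (0.80 log units; beyond the scatter), beyond the usual scatter. Compound 3 is therefore estimated at 3000 nM, with a likely range from 600 nM to 15000 nM.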

Compound 3, half-maximal inhibitory concentration: > 10000 nM
Compound 3 ended at the assay's limit; the forecaster's own chance of this, stated with the estimate: 35%; middle value at least 3.3-fold (0.52 log units) away from the limit.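

For the compounds shown here, exchanging the (tert-butyl)carbonyl for pyridin-4-yl on this aromatic carbon next to the ring nitrogen gives an at least 20-fold higher number from compound 2 to compound 3 (1.31 log units; beyond the scatter) in this assay and is the first measured sign that the group here matters, with the rest of the molecule unchanged. The group that leaves and the group that enters have the same number of heavy atoms and of hydrogen-bond acceptors, so these counts alone do not separate a compound with a measured value from one without. As far as these compounds go, compound 3 gives > 10000 nM and this is a limit of the assay and not a number, so the full size of the step stays unknown.

The compounds shown leave open whether a smaller acyl group such as acetyl, or a methyl ester, would keep inhibition at this position. They also leave open whether a plain phenyl ring or pyridin-3-yl would behave like pyridin-4-yl, which would show whether the ring itself or the place of its nitrogen counts for more.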